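The source may report more compounds than this note shows. Statements on the series, on what has been measured and on what is new or still open speak of the compounds shown alone.

Three close relatives of one shared core have been tested in a functional assay on SK-LU-1 cells (Homo sapiens) for antiproliferative activity, read by sulforhodamine B assay, with a stated time of 48 h, tested at 50 uM; a higher number here means more inhibition at the concentration tested (going by the name of the read-out), a lower number less inhibition. Compound 1, `CC1=CC[C@H](C(C)C)c2cc(C)c(OC(=O)c3ccc(Cl)cc3)cc21`, carries a 4-chlorophenyl on its carbonyl carbon, and in this assay compound 1 gives 17.4%. Compound 2, `COc1ccc(C(=O)Oc2cc3c(C)ccc(C(C)C)c3cc2C)cc1`, gives 32.8% in this assay, a number higher than that of compound 1 by more than the usual scatter. Compound 3, `CC1=CC[C@H](C(C)C)c2cc(C)c(OC(=O)c3ccc(C(F)(F)F)cc3)cc21`, is reported in this assay as "not active" (no number reported), without a number. Among the two compounds with numbers, compound 1 therefore stands lowest, and the third entry offers no number at all.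

Compound 4, `CC1=CC[C@H](C(C)C)c2cc(C)c(OC(=O)Nc3ccccc3)cc21`, is the next compound to be measured in this assay. Its difference from compound 1 is anilino in place of 4-chlorophenyl on a carbonyl carbon. For the measured compounds named here, no step between two measured compounds that differ in only one place is available here, so there is no measured precedent for a change of this kind.

The inhibition of compound 4 is expected to sit close to that of compound 1, with a step of a number 2.6 percentage points higher from compound 1 to compound 4 (within the scatter) that is not expected to go clearly beyond the scatter in either direction. The estimate for compound 4 in this assay is 20%, with a range from 5% to 40%.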

Compound 4, a percentage reported as inhibition, at one concentration (the size of the read-out at that concentration, not a potency): 100%
Estimate against measurement, compound 4: 80 percentage points below; measured number above the stated range.
By their numbers in this assay, from the lowest: compound 1; then compound 2; then compound 4.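

In this assay, replacing 4-chlorophenyl with anilino on a carbonyl carbon gives a number 82.6 percentage points higher from compound 1 to compound 4 (beyond the scatter), which shows that this position can strongly change the read-out. The change is also a narrow one: both groups hold an aromatic ring of carbon only, and the printed differences are that chlorine leaves while nitrogen enters, bringing a hydrogen-bond donor that 4-chlorophenyl lacks. No measurement here explains why this exchange has so large an effect on inhibition.

From the compounds shown here alone, it remains open whether the step belongs to the nitrogen link or to the loss of chlorine, and a 4-chloroanilino group on the same carbonyl carbon would separate the two, while a cyclohexylamino group would test whether the aromatic ring is needed. The read-out also comes from one concentration, so it gives no potency for compound 4 and does not show how far inhibition would persist at lower concentrations.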